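The source may hold more compounds than are shown below. What is called first, only, known or untested is meant among the compounds shown, and "the series" means these compounds.

In an assay on membranes from Sf9 cells for displacement of a labelled ligand from histamine H2 receptor (Homo sapiens), read by scintillation counting, with a stated time of 60 min (a lower number here means a stronger inhibitor, a higher number a weaker inhibitor), compound 3, `Cc1nc(N)sc1CCCN/C(N)=N/C(=O)NCc1ccco1`, gives 10.5 nM, the lowest of the three numbers in hand. Compound 1, `Cc1nc(N)sc1CCCN/C(N)=N/C(=O)N[C@H](C)c1ccccc1`, gives 17.8 nM, and compound 2, `Cc1nc(N)sc1CCCN/C(N)=N/C(=O)N[C@@H](C)c1ccccc1`, gives 51.3 nM. The step of a 2.9-fold higher number from compound 1 to compound 2 (0.46 log units; beyond the scatter) rests on (the fact that compounds 1 and 2 differ only in the configuration as drawn). The step of a 1.7-fold lower number from compound 1 to compound 3 (0.23 log units; within the scatter) lies within the scatter, whereas a 4.9-fold lower number from compound 2 to compound 3 (0.69 log units; beyond the scatter) is modest and beyond it; both exchange one group on the amide-type nitrogen for another. Compound 4, `Cc1nc(N)sc1CCCN/C(N)=N/C(=O)NCC(C)CC1CCCCC1`, has not yet been measured in this assay. It differs from compound 3 by 1-(cyclohexylmethyl)ethyl in place of furan-2-yl on a saturated chain carbon bound to an amide-type nitrogen. This change again swaps the group carried by the carbon bound to the amide-type nitrogen, and the measured steps of that kind run from within the scatter to a modest size, so a modest step is expected in this assay, toward a higher number, since the group that enters is larger and carries no acceptor. Compound 4 is therefore expected to give about 35 nM, within a range from 12 nM to 110 nM. The expected step of a 3.3-fold higher number from compound 3 to compound 4 (0.52 log units; beyond the scatter) is estimated to stay modest.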

Compound 4, inhibition constant: 70.8 nM
Compound 4: middle estimate off by 2.0-fold (0.31 log units), on the low side; low and high end bracket the measured number.
By their numbers in this assay, from the lowest: compounds 3 and 1 (each within the scatter of the next); then compounds 2 and 4 (each within the scatter of the next).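

In this assay, a 6.7-fold higher number from compound 3 to compound 4 (0.83 log units; beyond the scatter) shows that the group on a saturated chain carbon bound to an amide-type nitrogen can be exchanged with a change beyond the scatter, even when the group leaving is the furan-2-yl of the lowest number in hand. Among these compounds, earlier compounds all carried an aromatic ring here, so this is the first reading with a six-membered non-aromatic ring of carbon only and no hydrogen-bond acceptor in the group. Nothing at hand offers an explanation for this step.

The group entering differs from furan-2-yl in ring type, heavy atoms and acceptor count all at once, and the compounds shown do not separate these differences. From the compounds shown here alone, how a tetrahydrofuran-2-yl or a plain cyclohexyl would read on that same saturated chain carbon remains open.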